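Will compound 4 leave the assay limit?

A few compounds are considered here, and "the series" means these few. Any claim that something is new, unique, unknown or untested is made for them only; others in the source may bear on it.

The three compounds measured so far in a functional assay on MDA-MB-231 cells (Homo sapiens) for antiproliferative activity, read by CCK-8 assay, with a stated time of 48 h (on this read-out lower numbers stand for stronger inhibition and higher numbers for weaker inhibition), are:
- Compound 1 `CNC(=O)/C=C/CNCCOc1ccc(Oc2c(-c3ccc(F)cc3)sc3cc(O)ccc23)cc1` gives > 50000 nM as a limit
- Compound 2 `O=C(/C=C/CN1CC(Oc2ccc(Oc3c(-c4ccc(F)cc4)sc4cc(O)ccc34)cc2)C1)N1CCCC1` gives > 50000 nM as a limit
- Compound 3 `O=C(/C=C/CNCCOc1ccc(Oc2c(-c3ccc(F)cc3)sc3cc(O)ccc23)cc1)N1CCC1` gives > 50000 nM as a limit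

Compound 3 has no number of its own, and the same goes for compound 1 and compound 2, so what stands on record is the limit of > 50000 nM in this assay, at which 3 of the 3 values shown sit, and nothing finer.

The next structure is compound 4 `C=C(C)C(=O)N1CC(Oc2ccc(Oc3c(-c4ccc(F)cc4)sc4cc(O)ccc34)cc2)C1` and it keeps the shared core while exchanging a whole side chain: 1-((1-methylethenyl)carbonyl)azetidin-3-yl in place of 2-((3-((azetidin-1-yl)carbonyl)prop-2-en-1-yl)amino)ethyl on an oxygen on an aromatic ring. In words, 1-((1-methylethenyl)carbonyl)azetidin-3-yl comes in place of 2-((3-((azetidin-1-yl)carbonyl)prop-2-en-1-yl)amino)ethyl on an oxygen on an aromatic ring.

Among the compounds with values here, only one measured step bears on this change, namely a step that the two limits leave unreadable from compound 1 to compound 3 with azetidin-1-yl in place of methylamino on a carbonyl carbon. Its size cannot be read, so it gives no measure of how far a change can move a compound in this assay here. The expectation therefore rests on compound 3, whose > 50000 nM is a limit. No step beyond the usual scatter is expected, and another limit is the likeliest report, although the exchange is large enough to leave a lower number possible. The estimated step is a number no higher from compound 3 to compound 4 (the limit leaves the size open) in this reading. For compound 4 the estimate is 50000 nM with an expected range from 15000 nM to 100000 nM as its likely span.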

Compound 4, half-maximal inhibitory concentration: > 50000 nM
Compound 4: a limit, no number; the forecaster's own chance of this, stated with the estimate: 70%; the middle value lies on the limit itself.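

Compound 4 also comes back as a limit in this assay, so the steps to it from compound 1, compound 2 and compound 3 cannot be read, and the record stays as it was: the limit of > 50000 nM in this assay, at which 4 of the 4 values shown sit.

The compounds shown leave open how strongly any of them acts on these cells, and which structural change would give a measurable number.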